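The source may hold more compounds than are shown below. What is called first, only, known or untested is meant among the compounds shown, and "the series" means these compounds.

Measured compounds and values:

Compound 1, `CC1(C)[C@H]2CC[C@]1(C)N(Cc1cn(-c3cccc(C#N)c3)nn1)C(=O)C2`: in a functional assay on A549 cells (Homo sapiens) for inhibition, read by MTT assay, with a stated time of 24 h (a higher number here means a weaker inhibitor, a lower number a stronger inhibitor), compound 1 gives 440 nM.
Compound 2, `Cc1ccc(-n2cc(CN3C(=O)C[C@@H]4CC[C@@]3(C)C4(C)C)nn2)cc1`: in this assay compound 2 gives 400 nM.

Compound 2 carries the smaller of the two numbers, but only by a 1.1-fold lower number from compound 1 to compound 2 (0.04 log units; within the scatter), a step that lies within the scatter, so the two compounds cannot be told apart on these data. The next compound, compound 3, `COc1ccc(-n2cc(CN3C(=O)C[C@@H]4CC[C@@]3(C)C4(C)C)nn2)cc1`, differs from compound 2 by methoxy in place of methyl on an aromatic carbon. Going by the values given here, no measured step concerns this change: the single step, from compound 1 to compound 2, swaps one whole aryl group for another on an aromatic nitrogen and says nothing about methoxy against methyl. With no guidance from the measured pairs, the step from compound 2 to compound 3 is expected to be no change at the digits printed from compound 2 to compound 3 (within the scatter), nothing beyond the scatter. Compound 3 is therefore estimated at 400 nM in this assay, with a range from 180 nM to 900 nM.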

Compound 3, half-maximal inhibitory concentration: 50 nM
Compound 3: the middle estimate sits 8.0-fold (0.90 log units) above what was measured, and the stated range ends above it.
By their numbers in this assay, from the lowest: compound 3; then compounds 2 and 1 (each within the scatter of the next).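

Methoxy in place of methyl on this aromatic carbon, para to a large group, gives an 8.0-fold lower number from compound 2 to compound 3 (0.90 log units; beyond the scatter) in this assay and so shows that the group at this place matters, which the step between compound 1 and compound 2 could not show. The change to 4-methoxyphenyl from 3-cyanophenyl gives an 8.8-fold lower number from compound 1 to compound 3 (0.94 log units; beyond the scatter) in the same assay, so compound 3 stands apart from both earlier compounds. Nothing in the material at hand accounts for this step.

The compounds shown leave open whether the oxygen of methoxy is what counts, which a hydroxyl, an ethoxy or a dimethylamino group at the same carbon would begin to test. They also leave open whether methoxy gives a similar step at another place on the ring.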